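Working notes: 3-aminopropyl to 3-(dimethylamino)propyl

The compounds below may be only part of what the source reports. "The series", "measured", "known", "first", "only" and "open" are said of these compounds alone.

In a functional assay on MCF7 cells (Homo sapiens) for cytotoxicity, read by MTT assay, with a stated time of 72 h (a higher number here means a weaker inhibitor, a lower number a stronger inhibitor), compound 1 (`O=C(NCc1ccc(F)cc1)c1nc(NCCO)c2cccnc2c1O`) carries the entry "not determined" (no result reported) and compound 2 (`O=C(NCc1ccc(F)cc1)c1nc(Br)c2cccnc2c1NCCCNc1c(C(=O)NCc2ccc(F)cc2)nc(Br)c2cccnc12`) carries the entry "not determined" (no result reported) with no number behind either. Among the compounds with values here, compound 3 (`NCCCNc1c(C(=O)NCc2ccc(F)cc2)nc(Br)c2cccnc12`) gives 6000 nM in this assay and is the only compound with a number so far, which leaves nothing to rank it against.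

Compound 4 (`CN(C)CCCNc1c(C(=O)NCc2ccc(F)cc2)nc(Br)c2cccnc12`) has yet to be measured. The change from compound 3 to compound 4 is dimethylamino in place of amino on a saturated chain carbon, three bonds along the chain from a nitrogen on an aromatic ring and it sits on a saturated chain carbon, three bonds along the chain from a nitrogen on an aromatic ring. The 3-aminopropyl group thus becomes 3-(dimethylamino)propyl.

Within the data shown here, no measured pair shows what such a change does, so any expectation here is weak. A step in this assay no larger than the usual scatter is expected, with neither direction favoured. This expectation rests on compound 3 alone, at 6000 nM as its only anchor, and a wide range is kept for that reason. The expected move is a 1.2-fold lower number from compound 3 to compound 4 (0.08 log units; within the scatter) and it remains an estimate only. For compound 4 the estimated value is 5000 nM with an expected range from 1500 nM to 15000 nM in this read-out.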

Compound 4, half-maximal inhibitory concentration: 7000 nM
Compound 4: the middle estimate sits 1.4-fold (0.15 log units) below what was measured; measured number inside the range.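

In this assay, within the data shown here, putting dimethylamino in place of amino on a saturated chain carbon, three bonds along the chain from a nitrogen on an aromatic ring, gives a 1.2-fold higher number from compound 3 to compound 4 (0.07 log units; within the scatter) and so provides the first readable step. In this one pair, the read-out does not separate the 3-aminopropyl end from the 3-(dimethylamino)propyl end, even though the entering group has more heavy atoms and carries no hydrogen-bond donor. No measured property of either compound bears on why the two read alike.

Among these compounds, the pair covers only this end group on this chain, and with no numbers for compounds 1 and 2, no step involving either can be read. Still open, on these data alone, is how this assay responds to a longer chain such as 4-aminobutyl, to a ring amine such as pyrrolidine or morpholine at the end of the propyl chain, or to a carboxylic acid in place of the amine.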